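Dichloroacetamide anilides: a second ring chloro at a new place

This account rests on a few compounds, and the source may have more. Where it says the series, first, only, none or still open, it means among the compounds named here.

Measured compounds and their values:
Compound 1, `O=C(Nc1cccc(Cl)c1)C(Cl)Cl`: 44500 nM
Compound 2, `O=C(Nc1cccc(SC(F)(F)F)c1)C(Cl)Cl`: 6540 nM
Compound 3, `O=C(Nc1cccc(Cl)c1Cl)C(Cl)Cl`: 180000 nM

All three were tested in a functional assay on Bel-7402 cells (Homo sapiens) for antiproliferative activity, read by MTT assay, with a stated time of 72 h; on this read-out higher numbers stand for weaker inhibition and lower numbers for stronger inhibition. Compound 1 stands second highest of the three numbers; its nearest neighbour is compound 3, reached by a 4.0-fold higher number from compound 1 to compound 3 (0.61 log units; beyond the scatter), and its furthest is compound 2, reached by a 6.8-fold lower number from compound 1 to compound 2 (0.83 log units; beyond the scatter).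

Compound 4, `O=C(Nc1cc(Cl)cc(Cl)c1)C(Cl)Cl`, has not been measured. It differs from compound 1 by chloro in place of hydrogen on an aromatic carbon; the entering group sits meta to a chloro group and meta to a group of 6 heavy atoms. For the measured compounds named here, only one measured step adds a chloro to the ring of compound 1, the step to compound 3, and there the number rose modestly but beyond the scatter. The new chloro in compound 4 sits at a different place, so that step is only a loose guide. A modest rise, or no change beyond the scatter, is therefore expected, with a 1.3-fold higher number from compound 1 to compound 4 (0.13 log units; within the scatter) as the estimated step. Compound 4 is expected to give about 60000 nM, within a range from 15000 nM to 200000 nM.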

Compound 4, half-maximal inhibitory concentration: 4650 nM
The estimate for compound 4 lay 13-fold (1.11 log units) above the measured number, and the stated range ends above it.
By their numbers in this assay, from the lowest: compounds 4 and 2 (each within the scatter of the next); then compound 1; then compound 3.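

In this assay, chloro in place of hydrogen, meta to a chloro group and meta to a group of 6 heavy atoms, gives a 9.6-fold lower number from compound 1 to compound 4 (0.98 log units; beyond the scatter), whereas the added chloro of compound 3 gave a 4.0-fold higher number from compound 1 to compound 3 (0.61 log units; beyond the scatter). For the compounds shown here, the same change therefore moves the number in opposite directions depending on where it enters the ring, something the single earlier chloro step could not show. Nothing available here accounts for this difference.

The compounds shown leave open whether this place favours chloro alone or whether a methyl group, a methoxy group or an amine there would also lower the number. They also leave open whether a chloro at this place would lower the number of compound 2, which carries (trifluoromethyl)sulfanyl in place of the first chloro.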